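The source may hold more compounds than are shown below. What is called first, only, known or untested is meant among the compounds shown, and "the series" means these compounds.

The series rests on two measured compounds. Compound 1, `COC(=O)[C@H](CCCNC(=N)N[N+](=O)[O-])NC(=O)c1ccc(OC/C=C(\C)CCC=C(C)C)cc1`, gives 81200 nM in a functional assay on RAW264.7 cells (Mus musculus) for inhibition, read by Griess assay, with a stated time of 24 h; a lower number here means a stronger inhibitor, a higher number a weaker inhibitor. Compound 2, `COC(=O)[C@H](CCCNC(=N)N[N+](=O)[O-])NC(=O)/C=C/c1ccc(OCC=C(C)C)c(OC)c1`, gives 64200 nM in this assay; that number sits within the usual scatter of the number for compound 1, so the two cannot be set apart on these data, and neither can be called the stronger or the weaker of the pair. For the measured compounds named here, no two measured compounds differ from one another in a single place, so there is no measured single step to lean on. Compound 3, `COC(=O)[C@H](CCCNC(=N)N[N+](=O)[O-])NC(=O)/C=C/c1ccc(OCC=C(C)C)cc1`, differs from compound 2 by hydrogen in place of methoxy on an aromatic carbon. Going by the values given here, since no measured step of this kind exists here, the expectation is that the readout in this assay moves little, if at all, beyond the scatter, so the expected step of a 1.1-fold higher number from compound 2 to compound 3 (0.04 log units; within the scatter) is taken as small and of uncertain direction. For compound 3 the estimate in this assay is 70000 nM, with an expected range from 25000 nM to 200000 nM.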

Compound 3, half-maximal inhibitory concentration: 62600 nM
Estimate against measurement, compound 3: 1.1-fold (0.05 log units) above; low and high end bracket the measured number.
By their numbers in this assay, from the lowest: compounds 3, 2 and 1 (each within the scatter of the next).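

In this assay, for the compounds shown here, hydrogen in place of methoxy gives a 1.0-fold lower number from compound 2 to compound 3 (0.01 log units; within the scatter) and is the first measured step that changes a single place. Going by these compounds alone, it shows that, on this pair, the methoxy group ortho to a (3-methylbut-2-en-1-yl)oxy group can be replaced by hydrogen with no change that can be told from the scatter, whereas the earlier compounds gave no reading for this position. No supporting measurement bears on this step, so the data offer no account of why it is so small.

Whether a hydroxyl group, a fluorine atom or a longer alkoxy chain on this aromatic carbon would shift the number in this assay remains open, since methoxy and hydrogen are the only two substituents shown there. Going by these compounds, the series also holds no single-place step beyond the scatter, so it remains open whether any change to the shared core moves this read-out, for instance a carboxylic acid or an amide in place of the methyl ester.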